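Replacing diethylamino with dimethylamino on compound 2

The source may hold more compounds than are shown below. What is called first, only, known or untested is meant among the compounds shown, and "the series" means these compounds.

Compound 1 `CN(C)Cc1ccc2nc(NC(=O)N/N=C/c3cn(Cc4ccc(C(C)(C)C)cc4)c4ccccc34)sc2c1`: 810 nM
Compound 2 `CCN(CC)Cc1ccc2nc(NC(=O)N/N=C/c3cn(Cc4ccc(Cl)cc4)c4ccccc34)sc2c1`: 370 nM

Both values come from a functional assay on NCI-H460 cells (Homo sapiens) for cytotoxicity, read by MTT assay, with a stated time of 72 h (a lower number here means a stronger inhibitor, a higher number a weaker inhibitor), and make up the whole of the measured record. Compound 2 holds the lower of the two numbers at 370 nM and compound 1 stands higher at 810 nM with a gap beyond the usual scatter.

Compound 3 `CN(C)Cc1ccc2nc(NC(=O)N/N=C/c3cn(Cc4ccc(Cl)cc4)c4ccccc34)sc2c1` has no value yet in this assay and differs from compound 2 in one place. The change dimethylamino in place of diethylamino on a saturated chain carbon bound to an aromatic carbon puts dimethylamino in place of diethylamino on a saturated chain carbon bound to an aromatic carbon.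

Among the measured compounds shown here, no two measured compounds differ in one place only, so no measured step bears on this change. The expectation is therefore for no shift beyond the scatter in either direction, with compound 2 at 370 nM as the starting point. The expected step is a 1.1-fold higher number from compound 2 to compound 3 (0.03 log units; within the scatter) and lies within the scatter. Compound 3 is estimated at 400 nM with an expected range from 170 nM to 900 nM in this measurement.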

Compound 3, half-maximal inhibitory concentration: 290 nM
Estimate against measurement, compound 3: 1.4-fold (0.14 log units) above; the range from low to high includes it.
By their numbers in this assay, from the lowest: compounds 3 and 2 (each within the scatter of the next); then compound 1.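

In this assay, the shift from diethylamino to dimethylamino on a saturated chain carbon bound to an aromatic carbon gives a 1.3-fold lower number from compound 2 to compound 3 (0.11 log units; within the scatter) and so leaves the two amines indistinguishable in this measurement, even with two fewer carbons in the group. Among the compounds shown here, compound 3 also supplies the first one-place comparison at the other end of the molecule: chloro in place of tert-butyl on an aromatic carbon gives a 2.8-fold lower number from compound 1 to compound 3 (0.45 log units; beyond the scatter) and, unlike the amine change, this step separates the two compounds it joins. Nothing measured here offers an explanation for either step.

On these data alone, each step rests on a single pair of compounds, so it remains open whether the change from tert-butyl to chloro would have the same size with diethylamino in place of dimethylamino. The compounds shown also do not tell how a cyclic amine such as morpholine or pyrrolidine would read on that chain carbon, or how a fluoro or methoxy group would read in place of chloro.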